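Moving the substituent on the alkynyl phenyl ring of an mGlu5 modulator

This account rests on a few compounds, and the source may have more. Where it says the series, first, only, none or still open, it means among the compounds named here.

Measured compounds:
Compound 1, `Cc1ccccc1C#Cc1ccc2c(n1)CCN(C)C2=O`, gives 776 nM.
Compound 2, `Cc1cccc(C#Cc2ccc3c(n2)CCN(C)C3=O)c1`, gives 2.9 nM.
Compound 3, `Cc1ccc(C#Cc2ccc3c(n2)CCN(C)C3=O)cc1`, gives 1400 nM.

These three compounds share one core and differ only in the methyl-bearing phenyl ring attached to the triple bond. In a functional assay on HEK293 cells for negative allosteric modulation of metabotropic glutamate receptor 5 (Homo sapiens), read by FLIPR and calcium flux (a higher number here means a weaker inhibitor, a lower number a stronger inhibitor), compound 3 has the highest number of the three; compound 1 lies close to it, the difference a 1.8-fold higher number from compound 1 to compound 3 (0.26 log units; within the scatter) being within the scatter, while compound 2 lies far away: a 480-fold higher number from compound 2 to compound 3 (2.68 log units; beyond the scatter).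

Compound 4, `CN1CCc2nc(C#Cc3cccc(Cl)c3)ccc2C1=O`, has not been measured. The change from compound 3 is 3-chlorophenyl in place of 4-methylphenyl on a triple-bonded carbon. Going by the values given here, two measured steps bear on it. Moving a methyl from 2-methylphenyl to 3-methylphenyl gave a 270-fold lower number from compound 1 to compound 2 (2.43 log units; beyond the scatter), and moving it from 3-methylphenyl to 4-methylphenyl gave a 480-fold higher number from compound 2 to compound 3 (2.68 log units; beyond the scatter). Among the compounds with values here, compound 4 carries its substituent in the 3-chlorophenyl pattern, the same as the 3-methylphenyl of compound 2, although the exchange of methyl for chlorine has no measured counterpart here. A large fall in the number is therefore expected for compound 4: a 280-fold lower number from compound 3 to compound 4 (2.45 log units; beyond the scatter). Such a fall would roughly reverse the measured step of a 480-fold higher number from compound 2 to compound 3 (2.68 log units; beyond the scatter). Compound 4 is estimated at 5 nM, within a range of 1 nM to 40 nM.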

Compound 4, half-maximal inhibitory concentration: 22 nM
Compound 4: the middle estimate sits 4.4-fold (0.64 log units) below what was measured, and the stated range covers the measured number.
By their numbers in this assay, from the lowest: compound 2; then compound 4; then compounds 1 and 3 (each within the scatter of the next).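

In this assay, going by these compounds alone, chloro in place of methyl on an aromatic carbon is the first change here that alters the group rather than where it sits, and it gives a 7.6-fold higher number from compound 2 to compound 4 (0.88 log units; beyond the scatter) as a real but modest loss. Compound 4 still keeps a wide lead over the other two ring patterns, with a 64-fold lower number from compound 3 to compound 4 (1.80 log units; beyond the scatter) and a 35-fold lower number from compound 1 to compound 4 (1.55 log units; beyond the scatter) as the steps, so among these compounds strong inhibition with a 3-substituted phenyl is not limited to methyl, although each of these two steps changes both the group and its place. No measurement shown here explains the difference between chloro and methyl.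

As far as these compounds go, whether a 2-chlorophenyl or 4-chlorophenyl ring would lose as much as its methyl counterpart remains open. So does how a 3-methoxyphenyl or 3-aminophenyl ring would compare with compound 2 and compound 4.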